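This account rests on a few compounds, and the source may have more. Where it says the series, first, only, none or still open, it means among the compounds named here.

Three compounds have been measured so far in a functional assay (Nicotiana tabacum) (on this read-out lower numbers stand for stronger inhibition and higher numbers for weaker inhibition), so far:
Compound 1 (`CNc1nc(SC)nc2ncccc12`) gives 2920 nM
Compound 2 (`CCCCCNc1nc(SC)nc2ncccc12`) gives 650 nM
Compound 3 (`CSc1nc(Nc2ccc(F)cc2)c2cccnc2n1`) gives 2620 nM

Compound 3 lies within the usual scatter of compound 1, and its number is higher than that of compound 2. Compound 4 (`COc1ccc(Nc2nc(SC)nc3ncccc23)cc1`) carries methoxy in place of fluoro on an aromatic carbon, para to a large group (methoxy in place of fluoro on an aromatic carbon). For the measured compounds named here, the only measured step, a 4.5-fold lower number from compound 1 to compound 2 (0.65 log units; beyond the scatter), changes a chain on the nitrogen and not this ring, so it bears only weakly here. No change beyond the scatter is therefore expected in this assay, with an estimated 1.0-fold lower number from compound 3 to compound 4 (0.02 log units; within the scatter) as the likely outcome. For compound 4 the estimate is 2500 nM, with an expected range from 900 nM to 7000 nM in this wide uncertainty.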

Compound 4, half-maximal inhibitory concentration: 9420 nM
Beside the measured number, compound 4's estimate is 3.8-fold (0.58 log units) below it, and the stated range ends below it.
By their numbers in this assay, from the lowest: compound 2; then compounds 3 and 1 (each within the scatter of the next); then compound 4.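

In this assay, the aromatic carbon para to a large group is sensitive to what it carries: methoxy in place of fluoro gives a 3.6-fold higher number from compound 3 to compound 4 (0.56 log units; beyond the scatter) and so weakens inhibition. For the compounds shown here, the earlier compounds could not show this, as their only measured step changes the chain on the nitrogen. No available evidence explains this loss.

As far as these compounds go, with only fluoro and methoxy compared on this carbon, it remains open how chloro, methyl or an amine would read there. From the compounds shown here alone, it also remains open whether a longer chain on the nitrogen would give a similar step.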